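Compound 4: Cyclobutyl for Propyl on the Amide Nitrogen

The source may report more compounds than this note shows. Statements on the series, on what has been measured and on what is new or still open speak of the compounds shown alone.

Compound 1 `CCN(Cc1ccccc1)C(=O)C1CCN(S(=O)(=O)c2ccccc2)CC1`: 69%
Compound 2 `CCN(Cc1cccc(Cl)c1)C(=O)C1CCN(S(=O)(=O)c2ccc3cn[nH]c3c2)CC1`: 77%
Compound 3 `CCCN(Cc1ccccc1C(F)(F)F)C(=O)C1CCN(S(=O)(=O)c2ccc3[nH]ncc3c2)CC1`: 94%

In a functional assay on CHO cells for positive allosteric modulation of muscarinic acetylcholine receptor M5 (Homo sapiens), read by calcium flux (a higher number here means a larger maximal response, a lower number a smaller maximal response), compound 3 gives the highest of the three numbers. The nearest is compound 2, whose value lies beyond the usual scatter below it, and the furthest is compound 1, also beyond the scatter below it. The three compounds differ from one another in several places at once, so no single change can be read from their values.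

Compound 4 `O=C(C1CCN(S(=O)(=O)c2ccc3[nH]ncc3c2)CC1)N(Cc1ccccc1C(F)(F)F)C1CCC1` differs from compound 3 in one place: cyclobutyl in place of propyl on an amide-type nitrogen. Within the data shown here, no pair among the measured compounds shows this change, so its effect is not known from the data at hand. A small group on an amide nitrogen is exchanged for another small group of similar size, with no change in donors, acceptors or charge.

Against that background, the step from compound 3 to compound 4 in this assay is expected to be small, of uncertain direction, and most likely within the scatter, at a number 4 percentage points lower from compound 3 to compound 4 (within the scatter). Compound 4 is therefore estimated to reach 90% in this assay, with a likely range from 70% to 108%.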

Compound 4, largest response reached (reported as percent of maximum), in percent of the reference or control that the assay uses: 84%
Compound 4: middle estimate off by 6 percentage points, on the high side; measured number inside the range.
By their numbers in this assay, from the lowest: compounds 1, 2, 4 and 3 (each within the scatter of the next, the first and the last beyond it).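

This is the only pair shown that differs in one place, so it gives the first direct reading of the group on the amide-type nitrogen. In this assay, cyclobutyl in place of propyl gives a number 10 percentage points lower from compound 3 to compound 4 (within the scatter). At this position, then, an open chain of carbon can be replaced by a four-membered ring of carbon, with one more heavy atom and no added hydrogen-bond donors, acceptors or charge, and the maximal response stays within the scatter of the value for compound 3. Nothing measured here explains why the two groups read alike.

Going by these compounds, with a single pair at this position, it remains open how a methyl group, a longer chain such as pentyl, or a chain ending in an amine or a carboxylic acid would behave on this nitrogen. On these data alone, it is also open whether the exchange of propyl for cyclobutyl would read the same way with other groups elsewhere on the molecule, since compounds 1 and 2 differ from compound 3 in several places at once and cannot answer that.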